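A few compounds are considered here, and "the series" means these few. Any claim that something is new, unique, unknown or untested is made for them only; others in the source may bear on it.

Three closely related compounds have been tested in a functional assay on HeLa cells (Homo sapiens) for cytotoxicity, read by MTT assay, with a stated time of 2 days, tested at 10 uM; on this read-out lower numbers stand for a stronger effect and higher numbers for a weaker effect at the one concentration tested. Compound 1, `COc1ccc(-c2cc(C(C)=O)c3[nH]c(-c4ccccc4)cc3c2)cc1`, gives 33.9% in this assay. Compound 2, `COc1ccc(-c2cc(C(C)=O)c3[nH]c(-c4ccc(F)cc4)cc3c2)cc1`, differs from compound 1 by fluoro in place of hydrogen on an aromatic carbon, and in this assay compound 2 gives 46.5%; this change produced a number 12.6 percentage points higher from compound 1 to compound 2 (beyond the scatter). Compound 3, `CC(=O)c1cc(/C=C/c2ccccc2)cc2cc(-c3ccccc3)[nH]c12`, carries a different core, differing from compound 1 by 2-phenylethenyl in place of 4-methoxyphenyl on an aromatic carbon; in this assay compound 3 gives 52.5%, which amounts to a number 18.6 percentage points higher from compound 1 to compound 3 (beyond the scatter).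

Compound 4, `CC(=O)c1cc(/C=C/c2ccc(F)cc2)cc2cc(-c3ccccc3)[nH]c12`, has not yet been measured. It differs from compound 3 by fluoro in place of hydrogen on an aromatic carbon, the same change as that between compound 1 and compound 2, at a place described in identical words. In this assay, among the compounds with values here, the expected step is a number 11.5 percentage points higher from compound 3 to compound 4 (beyond the scatter), which rests on a single earlier pair because a number 12.6 percentage points higher from compound 1 to compound 2 (beyond the scatter) is the only measured example of this change, so the expectation is uncertain. Compound 4 is therefore estimated to give 64% in this assay, with a likely range from 50% to 78%.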

Compound 4, a percentage reported as activity, at one concentration (the size of the read-out at that concentration, not a potency): 32.8%
Beside the measured number, compound 4's estimate is 31.2 percentage points above it; measured number outside the range, below it.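

In this assay, fluoro in place of hydrogen on the 2-phenylethenyl group gives a number 19.7 percentage points lower from compound 3 to compound 4 (beyond the scatter), so a step measured on one core could not be carried to the other, where its direction reversed: the same change on two cores in this assay, a number 12.6 percentage points higher (beyond the scatter) from compound 1 to compound 2 and a number 19.7 percentage points lower (beyond the scatter) from compound 3 to compound 4, 32.3 percentage points apart, beyond the scatter of two such steps. With 2-(4-fluorophenyl)ethenyl in place of 4-methoxyphenyl, the comparison with the earlier compound gives a number 1.1 percentage points lower from compound 1 to compound 4 (within the scatter), so these two compounds cannot be told apart at this single concentration. The result does not show why the step reversed, nor does it give a rule for other cores, since each core offers a single pair and the fluoro sits on a different part of the molecule in compound 2 and compound 4.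

As far as these compounds go, it remains open whether fluoro on the phenyl group of compound 3 would follow compound 2 or compound 4. Also open, from the compounds shown here alone, is how chloro or an amine would behave at the same place on the 2-phenylethenyl group.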